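The source may report more compounds than this note shows. Statements on the series, on what has been measured and on what is new or still open speak of the compounds shown alone.

Compound 1 `Cc1cn([C@H]2C[C@H](CC3=CC(=O)C(=O)C=C3)[C@@H](CO[Si](C)(C)C(C)(C)C)O2)c(=O)[nH]c1=O`: no result reported in a functional assay on OVCAR-4 cells (Homo sapiens) for inhibition, read by sulforhodamine B assay, with a stated time of 48 h; on this read-out lower numbers stand for stronger inhibition of growth and higher numbers for weaker inhibition of growth
Compound 2 `COc1ccc(C2([C@H]3C[C@H](n4cc(C)c(=O)[nH]c4=O)O[C@@H]3CO[Si](C)(C)C(C)(C)C)SCCCS2)cc1OC`: 2880 nM

Within the data shown here, compound 2 is the only compound with a number in this assay, so nothing yet shows whether its value is strong or weak for this family. Compound 3 `COc1ccc(C2([C@H]3C[C@@H](n4cc(C)c(=O)[nH]c4=O)O[C@@H]3CO[Si](C)(C)C(C)(C)C)SCCCS2)cc1OC` has the same atoms and bonds, and the change is one of configuration as drawn: the two compounds have the same atoms and bonds and differ only in configuration as drawn: 1 of 3 stereo elements differ; a stereocentre at a saturated ring carbon is drawn R in compound 2 and S in compound 3, at a saturated ring carbon. Among the measured compounds shown here, no measured step shows what such a change does here, so neither direction can be favoured. The expected 1.0-fold higher number from compound 2 to compound 3 (0.02 log units; within the scatter) stays within the usual scatter. Compound 3 is estimated at 3000 nM, with an expected range of 1000 nM to 10000 nM.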

Compound 3, concentration for 50% growth inhibition: 4900 nM
For compound 3 the middle estimate is 1.6-fold (0.21 log units) below the measured one; the measured number falls inside the stated range.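

In this assay the series now has its first measured step, a 1.7-fold higher number from compound 2 to compound 3 (0.23 log units; within the scatter). The comparison is a clean one: the fact that compounds 2 and 3 differ only in the configuration as drawn. Swapping this saturated ring carbon from R to S therefore leaves the two values indistinguishable on this read-out, so growth inhibition here shows no clear dependence on the configuration at this centre.

A single pair cannot show whether that holds for the whole family. Going by these compounds, it remains open whether this centre would matter more with a free hydroxyl group or an amine in place of the silyl ether.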